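The compounds below may be only part of what the source reports. "The series", "measured", "known", "first", "only" and "open" are said of these compounds alone.

In an ADME assay on MT4 cells (Homo sapiens) for cytotoxicity, read by MTT assay (on this read-out higher numbers stand for lower toxicity in this test and lower numbers for higher toxicity in this test), compound 1 `Cc1cc(C)cc(S(=O)(=O)c2c(C(=O)NCC(=O)NCc3ccco3)[nH]c3ccc(Cl)cc23)c1` gives > 50000 nM, which is a limit of the test and not a number.
Compound 2 `Cc1cc(C)cc(S(=O)(=O)c2c(C(=O)NC(C)c3cc(F)cc(F)c3)[nH]c3ccc(Cl)cc23)c1` gives > 49700 nM, again a limit.
Compound 3 `Cc1cc(C)cc(S(=O)(=O)c2c(C(=O)NCc3n[nH]c4ccccc34)[nH]c3ccc(Cl)cc23)c1` gives > 50700 nM, also a limit.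

Since every value is a limit, compound 1 stands only at a boundary of this assay, and the steps a step that the two limits leave unreadable from compound 1 to compound 2 and a step that the two limits leave unreadable from compound 1 to compound 3 cannot be read for size or direction. Compound 4 `Cc1cc(C)cc(S(=O)(=O)c2c(C(=O)NC(C)C(=O)NCc3ccncn3)[nH]c3ccc(Cl)cc23)c1` differs from compound 1 in one place: a group of 12 heavy atoms (8 carbon, 3 nitrogen, 1 oxygen; one six-membered aromatic ring with 2 hetero atoms) in place of a group of 10 heavy atoms (7 carbon, 1 nitrogen, 2 oxygen; one five-membered aromatic ring with 1 hetero atom), on an amide-type nitrogen. The steps among compounds 1, 2 and 3 give no size for such a change. The change a step that the limit leaves unreadable from compound 1 to compound 4 is an expectation only. Because compound 1 sits at the limit of > 50000 nM in this assay, at which 1 of the 3 values shown sits, and the other two compounds sit at the limit of > 49700 nM in this assay, at which 1 of the 3 values shown sits, and (the limit of > 50700 nM in this assay, at which 1 of the 3 values shown sits), compound 4 is expected to give 60000 nM, with a range from 30000 nM to 200000 nM, most likely reported once more as a limit.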

Compound 4, half-maximal cytotoxic concentration: 28100 nM
For compound 4 the middle estimate is 2.1-fold (0.33 log units) above the measured one; measured number outside the range, below it.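

In this assay, within the data shown here, compound 4 is the only compound of the four that gives a number and not a limit, so this change on an amide-type nitrogen is the first that can be read in a direction. The steps read an at least 1.7-fold lower number from compound 1 to compound 4 (0.25 log units; that floor lies within the scatter), an at least 1.8-fold lower number from compound 3 to compound 4 (0.25 log units; that floor lies within the scatter) and an at least 1.7-fold lower number from compound 2 to compound 4 (0.24 log units; that floor lies within the scatter). Each is only a floor that stays within the scatter, because compound 1 stands at a limit: the limit of > 50000 nM in this assay, at which 1 of the 4 values shown sits.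

Which part of the entering group goes with the lower number stays open. So does what an amine or a carboxylic acid in that place would give.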